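The source may hold more compounds than are shown below. What is called first, only, known or untested is meant among the compounds shown, and "the series" means these compounds.

Measured so far in a functional assay on NIH3T3 cells (Mus musculus); a higher number here means that more compound is needed for the effect, a lower number that less compound is needed:
- compound 1 `Cn1cncc1C(OCc1ccc(C#N)cc1C#Cc1ccccn1)c1ccc(C#N)cc1`: > 0.1 nM (a limit)
- compound 2 `Cn1cncc1C(OCc1ccc(C#N)cc1/C=C/c1ccccn1)c1ccc(C#N)cc1`: 23.1 nM
- compound 3 `Cn1cncc1C(OCc1ccc(C#N)cc1C#Cc1cccc(O)c1)c1ccc(C#N)cc1`: > 0.1 nM (a limit)

Compound 3 stands on a limit only, > 0.1 nM, and has no number. That limit is shared: the limit of > 0.1 nM in this assay, at which 2 of the 3 values shown sit. Within the data shown here, compound 2 carries the only number in the set, 23.1 nM.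

The next compound, compound 4 `Cn1cncc1C(OCc1ccc(C#N)cc1C#Cc1ccccc1)c1ccc(C#N)cc1`, has hydrogen in place of hydroxy on an aromatic carbon of a six-membered aromatic ring of carbon only, meta to a large group, so that 3-hydroxyphenyl becomes phenyl (hydrogen in place of hydroxy on an aromatic carbon).

The measured step closest to this change is a step that the two limits leave unreadable from compound 1 to compound 3, with 3-hydroxyphenyl in place of pyridin-2-yl on a triple-bonded carbon. The other two steps, a step that the limit leaves unreadable from compound 1 to compound 2 and a step that the limit leaves unreadable from compound 2 to compound 3, give no size either. Among the measured compounds shown here, no measured step therefore gives a size or direction for removing the hydroxy, and no step beyond the scatter can be argued. Compound 4 may also end as a limit.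

With compound 2 at 23.1 nM as the only numerical anchor, a value in that region is expected, with wide margins. In this assay the expected change is a step that the limit leaves unreadable from compound 3 to compound 4, an estimate with no measured size behind it. Compound 4 is estimated at 25 nM, with an expected range of 3 nM to 200 nM.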

Compound 4, half-maximal effective concentration: 0.1 nM
Beside the measured number, compound 4's estimate is 250-fold (2.40 log units) above it, outside the stated range (below it).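

In this assay the series gains its first readable size, a 230-fold lower number from compound 2 to compound 4 (2.36 log units; beyond the scatter), for 2-phenylethynyl in place of 2-(pyridin-2-yl)ethenyl on an aromatic carbon. That single step exchanges both the ethenyl link for an ethynyl link and pyridin-2-yl for phenyl, so its size describes the pair of changes together and cannot be given to either one. Compound 4 also supplies a number for the phenyl end of the ethynyl series. For hydrogen in place of hydroxy on an aromatic carbon the data give a number no higher from compound 3 to compound 4 (the limit leaves the size open) and for phenyl in place of pyridin-2-yl on a triple-bonded carbon they give a number no higher from compound 1 to compound 4 (the limit leaves the size open) and neither size can be read, so hydrogen in place of hydroxy still has no size, because compound 1 and compound 3 rest on a limit only: the limit of > 0.1 nM in this assay, at which 2 of the 4 values shown sit.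

Open, from the compounds shown here alone, is how much of the large step belongs to the triple bond and how much to phenyl, and where compound 1 and compound 3 lie as numbers rather than limits. Also open, going by these compounds, is how a methoxy group or an amine would read in this assay on the aromatic carbon that carries hydroxy in compound 3.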